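The source may report more compounds than this note shows. Statements on the series, on what has been measured and on what is new or still open speak of the compounds shown alone.

Compound 1, `ClCc1cccc(Cn2cnc3c(Cl)nc(Cl)nc32)c1`, sits at the limit of a functional assay on HT-29 cells (Homo sapiens) for cytotoxicity, read by sulforhodamine B assay, with a stated time of 48 h; a lower number here means that less compound is tolerated, a higher number that more compound is tolerated: in this assay compound 1 gives > 100000 nM, which is a limit rather than a number. Compound 2, `ClCc1cccc(Cn2cnc3nc(Cl)nc(Cl)c32)c1`, has no single number here; in this assay compound 2 is reported as "not determined" (no result reported). Of the two values shown, one sits at the limit of > 100000 nM in this assay, at which 1 of the 2 values shown sits. Compound 3, `ClCc1cccc(Cn2cnc3ncnc(Cl)c32)c1`, differs from compound 2 by hydrogen in place of chloro on an aromatic carbon. Within the data shown here, with no measured step to go by, no shift beyond the usual scatter is expected in this assay. Compound 3 is therefore expected to give about 100000 nM, estimated between 30000 nM and 300000 nM.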

Compound 3, concentration lethal to 50% of the cells: 6020 nM
Estimate against measurement, compound 3: 17-fold (1.22 log units) above, and the stated range ends above it.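

No step can be read for compound 3, as compound 2, which differs from it in one place, has no result in this assay. What the chloro group on that aromatic carbon contributes stays open, and nothing shown bears on it.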